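Glycinamide series: estimate for compound 4 from compound 2

A few compounds are considered here, and "the series" means these few. Any claim that something is new, unique, unknown or untested is made for them only; others in the source may bear on it.

Measured compounds:
- compound 1 `O=C(O)[C@@H]1CCCN1C(=O)CN(c1nc(Cl)nc2[nH]cnc12)C1CC1`: 34.9%
- compound 2 `O=C(CN(c1ncnc2c1ncn2C1CCCCO1)C1CC1)N[C@@H](CO)C(=O)OCc1ccccc1`: 46.7%
- compound 3 `N=C(N)NCCC[C@H](NC(=O)CN(c1nc(Cl)nc2[nH]cnc12)C1CC1)C(=O)O`: 51%

In a functional assay on the whole organism (Tail, strain ICR) with Mus musculus as the target, in the tail flick test, with a stated time of 60 min, at a dose of 25 umol/kg by the oral route (on this read-out lower numbers stand for a weaker effect and higher numbers for a stronger effect at the one dose given), compound 1 gives 34.9%, compound 2 gives 46.7% and compound 3 gives 51%. Compound 2 stands second highest of the three numbers; compound 3 lies within the scatter of compound 2, while compound 1 lies beyond it on the lower side. Compound 4 `O=C(CN(c1ncnc2c1ncn2C1CCCCO1)C1CC1)N[C@@H](CCC(=O)OCc1ccccc1)C(=O)OCc1ccccc1` differs from compound 2 in one place: (benzyloxycarbonyl)methyl in place of hydroxy on a saturated chain carbon, two bonds along the chain from an amide-type nitrogen and a carbonyl carbon. Within the data shown here, no two measured compounds differ in a single place, so no measured step is available to guide the size of this change. The step from compound 2 to compound 4 is expected to be small, a number 1.3 percentage points higher from compound 2 to compound 4 (within the scatter), likely not beyond the scatter in this assay. Compound 4 is therefore estimated at 48%, with a range from 30% to 66%.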

Compound 4, a percentage reported as activity, at one dose (the size of the read-out at that dose, not a potency): 34.7%
The estimate for compound 4 lay 13.3 percentage points above the measured number; low and high end bracket the measured number.
By their numbers in this assay, from the lowest: compounds 4 and 1 (each within the scatter of the next); then compounds 2 and 3 (each within the scatter of the next).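

In this assay, the saturated chain carbon two bonds along the chain from an amide-type nitrogen and a carbonyl carbon proves sensitive to substitution: (benzyloxycarbonyl)methyl in place of hydroxy gives a number 12 percentage points lower from compound 2 to compound 4 (beyond the scatter). Among these compounds, this is the only single-place step available, and its size is modest. Nothing on hand bears on the reason for this step. The compounds shown leave open whether the benzyl ester or the added chain length carries the step. A carboxylic acid or an amine in place of hydroxy at this carbon remains an open comparison.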